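A few compounds are considered here, and "the series" means these few. Any claim that something is new, unique, unknown or untested is made for them only; others in the source may bear on it.

Of the compounds shown here, three have so far been measured in an in vitro functional assay on HEK285-7 cells for antagonist activity at prostaglandin D2 receptor 2 (Homo sapiens), read by BRET and beta-arrestin recruitment; on this read-out higher numbers stand for larger maximal responses and lower numbers for smaller maximal responses. Compound 1, with the structure `O=C(O)Cc1sc(COc2ccc(Cl)cc2)nc1-c1ccc(Cl)cc1`, reaches 50% in this assay. Compound 3, `Nc1nc(-c2ccc(Cl)cc2)c(CC(=O)O)s1`, reaches 50% in this assay as well. Compound 2, `N#Cc1cc(-c2nc(C(c3ccc(F)cc3)c3ccc(F)cc3)sc2CC(=O)O)ccc1F`, holds the highest of the three numbers: in this assay compound 2 reaches 80%, and the gap separating it from compound 1 and from compound 3 lies beyond the usual scatter in both cases.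

Compound 4, `O=C(O)Cc1sc(C(c2ccc(F)cc2)c2ccc(F)cc2)nc1-c1ccco1`, has not yet been measured in this assay. It is reached from compound 2 by a single change: furan-2-yl in place of 3-cyano-4-fluorophenyl on an aromatic carbon. Going by the values given here, no pair of measured compounds differs in only one place, so no directly comparable step is available. What the measured compounds do show is that the two compounds lacking the 3-cyano-4-fluorophenyl group, compound 1 with 50% and compound 3 with 50%, both sit well under compound 2. On that basis a decrease beyond the scatter is expected, of the size a number 22 percentage points lower from compound 2 to compound 4 (beyond the scatter). Compound 4 is therefore estimated to reach 58% in this assay, with a range from 40% to 78%.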

Compound 4, largest response reached (reported as efficacy), in percent of the reference or control that the assay uses: 80%
The estimate for compound 4 lay 22 percentage points below the measured number; measured number outside the range, above it.
By their numbers in this assay, from the lowest: compounds 1 and 3 (each within the scatter of the next); then compounds 2 and 4 (each within the scatter of the next).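

In this assay, placing furan-2-yl instead of 3-cyano-4-fluorophenyl on the aromatic carbon next to the ring nitrogen gives no change at the digits printed from compound 2 to compound 4 (within the scatter), the only step shown that isolates this position. It shows that, with the rest of compound 2 kept, the maximal response in this read-out does not depend on the six-membered carbon ring, its nitrile or its fluorine, since a five-membered aromatic ring with one oxygen and 5 heavy atoms instead of 9 serves equally well; compound 1 and compound 3 differ from compound 2 in more than one place, so their lower numbers cannot be tied to this group. No measured evidence is available to explain this result.

The compounds shown leave open whether this tolerance extends to groups of another kind at the same carbon, such as a methyl group, a primary amine or a piperidine ring. They also leave open whether furan-2-yl would behave in the same way if the large group on the other side of the core were replaced by a smaller one, such as an amine.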